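The source may report more compounds than this note shows. Statements on the series, on what has been measured and on what is new or still open speak of the compounds shown alone.

Of the compounds shown here, two have been measured in a functional assay on ileum for inhibition of histamine H1 receptor (Cavia porcellus); on this read-out higher numbers stand for weaker inhibition and lower numbers for stronger inhibition. Compound 1 `CCCOCCn1c(N2CCN(C)CC2)nc2ccccc21` gives 20 nM in this assay, and compound 2 `CCOCCn1c(N2CCCN(Cc3ccccc3)CC2)nc2ccccc21` gives 15 nM; the two numbers lie within the scatter of each other, so compound 1 stands level with compound 2 rather than apart from it. Compound 3 `CN1CCN(c2nc3ccccc3[nH]2)CC1` has not been measured. It differs from compound 1 in one place: hydrogen in place of 2-propoxyethyl on an aromatic nitrogen. Going by the values given here, no measured step covers such a change. Among the compounds with values here, the expected step of a 15-fold higher number from compound 1 to compound 3 (1.18 log units; beyond the scatter) is toward weaker inhibition, beyond the scatter, since the chain removed is the only feature shared by compound 1 and compound 2 beyond the core. Compound 3 is expected to give 300 nM, in a range from 60 nM to 2000 nM.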

Compound 3, half-maximal inhibitory concentration: > 3000 nM
Compound 3 was reported as a limit (the forecaster's own chance of this, stated with the estimate: 10%); middle value at least 10-fold (1.00 log units) from the limit.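

In this assay, hydrogen in place of 2-propoxyethyl on the aromatic nitrogen gives an at least 150-fold higher number from compound 1 to compound 3 (2.17 log units; beyond the scatter), a large step toward weaker inhibition. For compound 3, the value > 3000 nM is a limit of the assay. This shows that what sits on this nitrogen matters greatly for inhibition in this read-out, which compound 1 and compound 2, both carrying a chain there, could not show.

As far as these compounds go, what remains open is how a single methyl group on this nitrogen would read, and how a chain ending in an amine would.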